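3-Fluorobenzyl to 3,4,5-trifluorobenzyl on the shared core

The compounds below may be only part of what the source reports. "The series", "measured", "known", "first", "only" and "open" are said of these compounds alone.

Compound 1 `O=C(Nc1ccc(-c2cscn2)cc1)C1CCCN(C(=O)c2ccc(F)c(F)c2)C1` gives > 20000 nM as a limit
Compound 2 `O=C(Nc1ccc(-c2cscn2)cc1)C1CCCN(Cc2cccc(F)c2)C1` gives 5000 nM as a number

In a functional assay on A-375 cells (Homo sapiens) for activation, with a stated time of 3 days (on this read-out lower numbers stand for an effect already at smaller amounts and higher numbers for an effect only at larger amounts of compound), compound 1 shows > 20000 nM as a limit and not a number. Within the data shown here, compound 2 gives 5000 nM as the only true number in the set, so it has no measured neighbour to be ranked against. Compound 3 `O=C(Nc1ccc(-c2cscn2)cc1)C1CCCN(Cc2cc(F)c(F)c(F)c2)C1` keeps the core of compound 2 and carries 3,4,5-trifluorophenyl in place of 3-fluorophenyl on a saturated chain carbon bound to an amine nitrogen in a ring. Among the measured compounds shown here, one measured step bears on this, and only loosely: an at least 4.0-fold lower number from compound 1 to compound 2 (0.60 log units; beyond the scatter) is open at one end (the limit of > 20000 nM in this assay, at which 1 of the 2 values shown sits) and swapped a carbonyl for a benzyl group rather than changing fluorines alone. For the measured compounds named here, with that step as the only guide, no change beyond the scatter is expected in this assay for this fluorine change. The expected change is small, an estimated 1.4-fold lower number from compound 2 to compound 3 (0.15 log units; within the scatter) at most of modest weight. Compound 3 is estimated at 3500 nM with an expected range from 1000 nM to 12000 nM in this read-out.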

Compound 3, half-maximal effective concentration: 1260 nM
Compound 3: the middle estimate sits 2.8-fold (0.44 log units) above what was measured, and the stated range covers the measured number.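

Among these compounds, until this point the only measured step had replaced the whole group on the ring amine nitrogen, carbonyl link included. Here, in this assay, the benzyl link stays and 3,4,5-trifluorophenyl takes the place of 3-fluorophenyl, which alone gives a 4.0-fold lower number from compound 2 to compound 3 (0.60 log units; beyond the scatter). The fluorines on this phenyl ring, on a saturated chain carbon bound to an amine nitrogen in a ring, therefore matter in their own right in this read-out, not only the change from carbonyl to benzyl. Replacing (3,4-difluorophenyl)carbonyl with 3,4,5-trifluorobenzyl gives an at least 15-fold lower number from compound 1 to compound 3 (1.20 log units; beyond the scatter), a step open at one end: the limit of > 20000 nM in this assay, at which 1 of the 3 values shown sits.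

Whether both added fluorines contribute, or one of them accounts for the whole step, remains open. So does the outcome in this assay of a chlorine, a nitrile or a trifluoromethyl group on the benzyl ring, or of a longer chain such as phenethyl on the ring amine nitrogen.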